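The source may report more compounds than this note shows. Statements on the series, on what has been measured and on what is new or still open speak of the compounds shown alone.

In a functional assay on HeLa cells (Homo sapiens) for cytotoxicity, read by MTT assay, with a stated time of 2 days (a higher number here means a weaker inhibitor, a lower number a stronger inhibitor), compound 1 `Cc1ccc2c(=O)[nH]c(-c3cccc(F)c3)nc2c1` gives > 50000 nM, which is a limit and not a number. Compound 2 `Cc1ccc2c(=O)[nH]c(-c3cccc(OC(F)(F)F)c3)nc2c1` gives > 50000 nM, also a limit. Compound 3 `Cc1ccc2c(=O)[nH]c(-c3cccc(C(F)(F)F)c3)nc2c1` has trifluoromethyl in place of trifluoromethoxy on an aromatic carbon, meta to a large group: trifluoromethyl in place of trifluoromethoxy on an aromatic carbon. Going by the values given here, the only measured step is a step that the two limits leave unreadable from compound 1 to compound 2, and it offers no size to carry forward. The evidence so far is the limit of > 50000 nM in this assay, at which 2 of the 2 values shown sit. In this assay, no step beyond the scatter and no direction is expected, so the expected step is a step that the limit leaves unreadable from compound 2 to compound 3. For compound 3 the estimated value is 60000 nM, with an expected range of 30000 nM to 100000 nM.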

Compound 3, half-maximal inhibitory concentration: > 50000 nM
Compound 3 was reported as a limit (the forecaster's own chance of this, stated with the estimate: 90%); the middle value does not contradict the limit.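

No step can be read among compound 1, compound 2 and compound 3: in this assay all three values are limits and not numbers. The compounds shown leave open how these three truly compare, and whether any other group on that aromatic carbon would give a readable value.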